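This account rests on a few compounds, and the source may have more. Where it says the series, first, only, none or still open, it means among the compounds named here.

Of the compounds shown here, three have numbers so far in a functional assay on K562 cells (Homo sapiens) for inhibition, read by trypan blue exclusion, with a stated time of 72 h; on this read-out lower numbers stand for stronger inhibition and higher numbers for weaker inhibition. Compound 1 (`Cn1c(=O)c(S(=O)(=O)c2ccc(F)cc2F)cc2cnc(Nc3ccc4[nH]c(C(=O)O)cc4c3)nc21`) gives 10000 nM, and compound 2 (`Cn1c(=O)c(S(=O)(=O)c2ccc(F)cc2)cc2cnc(Nc3ccc4cc[nH]c4c3)nc21`) gives 10000 nM. Compound 3 (`Cn1c(=O)c(S(=O)(=O)Cc2ccc(F)cc2F)cc2cnc(Nc3ccc4[nH]ccc4c3)nc21`) gives 1000 nM, the lowest of the three numbers and beyond the scatter from each of the other two.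

The next compound to be read is compound 4 (`Cn1c(=O)c(S(=O)(=O)c2ccc(O)cc2)cc2cnc(Nc3ccc4[nH]ccc4c3)nc21`), which differs from compound 3 in one place: 4-hydroxyphenyl in place of 2,4-difluorobenzyl on a sulfonyl sulfur. This puts 4-hydroxyphenyl in place of 2,4-difluorobenzyl on a sulfonyl sulfur.

For the measured compounds named here, no measured pair differs in one place only, so no direct step supports this change. Going by the values given here, the only guide is the spread of values, with compound 3 at 1000 nM and compound 1 and compound 2 both higher. Compound 3 therefore sits at the low end of what has been seen, and a move toward weaker inhibition in this assay is more likely than a gain. The expected shift is modest, just beyond the scatter: a 3.0-fold higher number from compound 3 to compound 4 (0.48 log units; beyond the scatter). For compound 4 the estimated value is 3000 nM, with an expected range of 600 nM to 10000 nM.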

Compound 4, half-maximal inhibitory concentration: 100 nM
Compound 4: middle estimate off by 30-fold (1.48 log units), on the high side; the measured number lies below the stated range.
By their numbers in this assay, from the lowest: compound 4; then compound 3; then compounds 1 and 2 (each within the scatter of the next).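

In this assay, 4-hydroxyphenyl in place of 2,4-difluorobenzyl on a sulfonyl sulfur gives a 10-fold lower number from compound 3 to compound 4 (1.00 log units; beyond the scatter) with the rest of the structure unchanged. For the compounds shown here, this is the first direct reading of a one-place change, and it shows that this position can move the number well beyond the scatter, toward stronger inhibition. The entering group brings a hydrogen-bond donor and a hydrogen-bond acceptor and leaves out both fluorine atoms, but nothing on hand explains the fall.

Going by these compounds alone, the single step changes these features together, so it remains open whether the hydroxyl or the loss of the 2,4-difluorobenzyl matters more. A plain phenyl, a methoxyphenyl, an aminophenyl or a hydroxybenzyl on the same sulfonyl sulfur would help to separate these contributions.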